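This account rests on a few compounds, and the source may have more. Where it says the series, first, only, none or still open, it means among the compounds named here.

In a functional assay on the whole organism (strain Wistar albino) for inhibition, with Rattus norvegicus as the target, read by paw edema, with stated times of 30 min and 3 h, at a dose of 20 mg/kg by the oral route (a higher number here means more inhibition at the dose given (going by the name of the read-out), a lower number less inhibition), compound 1 `COc1ccc(-c2cc(=O)c3cc(CCl)ccc3o2)cc1` gives 38.7%, the lowest of the three numbers recorded. Compound 2 `COc1ccc(-c2cc(=O)c3cc(CN(C)C)ccc3o2)cc1` gives 53.1% in this assay, and the one-place change between them, dimethylamino in place of chloro on a saturated chain carbon bound to an aromatic carbon, brings a number 14.4 percentage points higher from compound 1 to compound 2 (beyond the scatter). For the measured compounds named here, compound 3 `COc1ccc(-c2cc(=O)c3cc(CNc4ccc(S(N)(=O)=O)cc4)ccc3o2)cc1` gives 60.5%; no single step connects it to compound 1, so the two values only show that compound 3 sits higher, beyond the scatter.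

Compound 4 `COc1ccc(-c2cc(=O)c3cc(CCl)ccc3o2)cc1OC` has not yet been measured. It differs from compound 1 by methoxy in place of hydrogen on an aromatic carbon. Going by the values given here, the only measured step, from compound 1 to compound 2, alters the saturated chain on the shared core, not the aromatic ring that carries the methoxy group, so it says nothing direct about the change to compound 4. Among the compounds with values here, with no step of this kind among the measured compounds, the expectation is that the new methoxy group leaves the inhibition of paw edema close to where compound 1 stands, with no step beyond the scatter, estimated as a number 2.3 percentage points higher from compound 1 to compound 4 (within the scatter). Compound 4 is therefore expected to give about 41% in this assay, within a range from 30% to 53%.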

Compound 4, a percentage reported as inhibition, in the whole organism at one dose (the size of the read-out at that dose, not a potency): 49.4%
Estimate against measurement, compound 4: 8.4 percentage points below, within the range that was stated.
By their numbers in this assay, from the lowest: compound 1; then compounds 4, 2 and 3 (each within the scatter of the next, the first and the last beyond it).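

For the compounds shown here, the step of a number 10.7 percentage points higher from compound 1 to compound 4 (beyond the scatter) in this assay is the first measured change on the aromatic ring that carries the methoxy group, and it lies beyond the scatter. Going by these compounds alone, until now, the only step read had been on the saturated chain, a number 14.4 percentage points higher from compound 1 to compound 2 (beyond the scatter), so this result shows that the read-out also responds to a change on an aromatic carbon ortho to a methoxy group and meta to a large group, with a methoxy group entering in place of a hydrogen atom and the chloro-bearing chain left as it was. Nothing at hand gives a reason for this step, whether for the gain itself or for its size.

The compounds shown leave open whether the methoxy step would carry over to compounds with dimethylamino or the sulfonamide-bearing aniline on the chain, since both of those sit on the core of compound 1 without the added methoxy group. They also leave open what a hydroxy group, an ethoxy group or a fluorine atom on the same aromatic carbon would do at this single oral dose, and whether a step of similar size would follow.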